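One Stereocentre Inverted on a Shared Core

This account rests on a few compounds, and the source may have more. Where it says the series, first, only, none or still open, it means among the compounds named here.

Of the compounds shown here, three built on the same core have been tested in an ADME assay on Vero cells (Chlorocebus sabaeus) for cytotoxicity, read by MTT assay, with a stated time of 48 h; a lower number here means that less compound is tolerated, a higher number that more compound is tolerated. Compound 1 `C=C1CC[C@@H]2[C@](C)(COC(C)=O)[C@H](O)CC[C@@]2(C)[C@@H]1C/C=C1/C(=O)OC[C@@H]1Oc1c(Cl)cc(Cl)c2cccnc12` gives 51900 nM. Compound 2 `C=C1CC[C@@H]2[C@](C)(CO)[C@H](O)CC[C@@]2(C)[C@@H]1C/C=C1/C(=O)OC[C@@H]1Oc1cccc2ccc(C)nc12` gives 99800 nM. Compound 3 `C=C1CC[C@@H]2[C@](C)(COC(C)=O)[C@H](O)CC[C@@]2(C)[C@@H]1C/C=C1/C(=O)OC[C@H]1Oc1cccc2ccc(C)nc12` gives 50600 nM. The three numbers lie close together: the gap from compound 3 to compound 1 and the gap from compound 3 to compound 2 both fall within the usual scatter of this assay, so none of the three can be set apart from the others on tolerance.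

Compound 4 `C=C1CC[C@@H]2[C@](C)(COC(C)=O)[C@H](O)CC[C@@]2(C)[C@@H]1C/C=C1/C(=O)OC[C@@H]1Oc1cccc2ccc(C)nc12` is the next compound, not yet measured. It differs from compound 3 as follows: the two compounds have the same atoms and bonds and differ only in configuration as drawn: 1 of 7 stereo elements differ; a stereocentre at a saturated ring carbon is drawn S in compound 3 and R in compound 4. No group is removed or added; only the drawn configuration at one saturated ring carbon changes.

For the measured compounds named here, no step between two measured compounds of this kind is available, so there is no measured precedent for what inverting a single stereocentre does here. Given that the three measured compounds all sit within scatter of one another, the expectation for compound 4 is a step in this assay that stays within the scatter, in either direction: a 1.1-fold higher number from compound 3 to compound 4 (0.04 log units; within the scatter). Compound 4 is therefore estimated at 55000 nM, with a likely range from 25000 nM to 120000 nM.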

Compound 4, half-maximal cytotoxic concentration: 46500 nM
The estimate for compound 4 lay 1.2-fold (0.07 log units) above the measured number; measured number inside the range.
By their numbers in this assay, from the lowest: compounds 4, 3, 1 and 2 (each within the scatter of the next, the first and the last beyond it).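

In this assay, inverting this one saturated ring carbon gives a 1.1-fold lower number from compound 3 to compound 4 (0.04 log units; within the scatter), so at this position the drawn configuration produces no change that can be told from scatter, and the comparison is a clean one, since no other structural difference is involved: the fact that compounds 3 and 4 differ only in the configuration as drawn

Swapping the group on the other side of the molecule gives a similar picture: with 2-methylquinolin-8-yl in place of 5,7-dichloroquinolin-8-yl, the result is a 1.1-fold lower number from compound 1 to compound 4 (0.05 log units; within the scatter). For the compounds shown here, the only step here that clears the scatter comes with acetyl in place of hydrogen on an oxygen on a saturated carbon, a 2.1-fold lower number from compound 2 to compound 4 (0.33 log units; beyond the scatter), and it is a modest one.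

As far as these compounds go, whether that acetyl step holds with the other drawn configuration stays open, as does what a benzoyl group in place of the acetyl, or an amine on the 2-methylquinolin-8-yl group, would do to the number. From the compounds shown here alone, these results also concern tolerance by these cells alone, so what the inversion does in any other assay remains unknown.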